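The source may hold more compounds than are shown below. What is called first, only, known or untested is meant among the compounds shown, and "the series" means these compounds.

Measured compounds:
compound 1 `COCC1=CS(=O)(=O)c2ccccc2C1=O` — 99.9%
compound 2 `COCCOCC1=CS(=O)(=O)c2ccccc2C1=O` — 98.2%

In a functional assay on the whole organism for inhibition, with Mus musculus as the target, at a dose of 10 mg/kg (a lower number here means less inhibition, a higher number more inhibition at the dose given (going by the name of the read-out)), compound 1 gives 99.9% and compound 2 gives 98.2%. For the measured compounds named here, the one step between them, a number 1.7 percentage points lower from compound 1 to compound 2 (within the scatter), lies within the scatter, so the two values are read as equal. Compound 2 stands as the lower of the two numbers, its nearest neighbour being compound 1, but the gap is within the scatter and no order is claimed.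

Compound 3 `CCC(=O)OCC1=CS(=O)(=O)c2ccccc2C1=O` is the next point. It differs from compound 2 by propanoyl in place of 2-methoxyethyl on an oxygen on a saturated carbon. Going by the values given here, the only measured step that bears on this position is a number 1.7 percentage points lower from compound 1 to compound 2 (within the scatter), which changed the group on the same oxygen on a saturated carbon and left the read-out within the scatter. That step exchanged one saturated chain for another; the present change brings in a propanoyl, so the precedent is only partial. Both measured values sit close to the top of the scale, which leaves little room for a rise.

Compound 3 is therefore expected to give 95% in this assay, within 80% to 100%. The expected step of a number 3.2 percentage points lower from compound 2 to compound 3 (within the scatter) is not beyond the scatter.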

Compound 3, a percentage reported as inhibition, in the whole organism at one dose (the size of the read-out at that dose, not a potency): 99.5%
For compound 3 the middle estimate is 4.5 percentage points below the measured one; the range from low to high includes it.
By their numbers in this assay, from the lowest: compounds 2, 3 and 1 (each within the scatter of the next).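

In this assay, propanoyl on the oxygen on a saturated carbon reads as equal to both earlier groups on that oxygen: a number 1.3 percentage points higher from compound 2 to compound 3 (within the scatter) against 2-methoxyethyl, and a number 0.4 percentage points lower from compound 1 to compound 3 (within the scatter) against methyl. The earlier pair covered only saturated chains, whereas this result extends the flat picture at this position to a group with a double bond outside aromatic rings, so methyl, 2-methoxyethyl and propanoyl cannot be told apart here. No measurement is available to explain why the read-out stays level across these three groups.

All three values lie close to the top of the scale at a single dose, so a real difference in potency between these compounds could stay hidden, and this position's limits remain undefined. Still open, as far as these compounds go, is whether the same level of inhibition would hold with a free hydroxyl, an amine or a carboxylic acid on this side chain, or with a much longer chain or a benzoyl group on the same oxygen.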